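Swapping One Aryl Group for Another in a Cytotoxicity Series

The source may report more compounds than this note shows. Statements on the series, on what has been measured and on what is new or still open speak of the compounds shown alone.

Of the compounds shown here, three have been tested in a functional assay on HeLa cells (Homo sapiens) for cytotoxicity, read by MTT assay, with a stated time of 48 h; on this read-out lower numbers stand for stronger inhibition and higher numbers for weaker inhibition. Compound 1, `COc1ccc(-c2c(-c3ccccc3)oc3cc(OC)ccc23)c(O)c1`, gives 28900 nM. Compound 2, `COc1cccc(-c2c(-c3ccccc3)oc3c(OC)cccc23)c1O`, gives 57800 nM. Compound 3, `Cc1ccccc1-c1oc2cc(O)ccc2c1-c1ccc(O)cc1O`, gives 47500 nM. Among the three numbers that of compound 3 sits in the middle, but its gaps to compound 2 and to compound 1 both lie within the usual scatter of this kind of measurement, so on the present evidence the three compounds cannot be told apart.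

Compound 4, `COc1cccc(-c2oc3cc(O)ccc3c2-c2ccc(O)cc2O)c1`, is not yet measured. It differs from compound 3 in one place: 3-methoxyphenyl in place of 2-methylphenyl on an aromatic carbon. Among the compounds with values here, since no pair of measured compounds differs in only one place, there is no measured step to say how a single change of this sort moves the read-out. The three measured numbers all sit close together, and a change of one aryl group for another of similar size gives no grounds to expect a departure from that cluster. The step from compound 3 to compound 4 is therefore expected to be a 1.1-fold lower number from compound 3 to compound 4 (0.02 log units; within the scatter), within the scatter. Compound 4 is expected to give about 45000 nM in this assay, with a range from 20000 nM to 100000 nM.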

Compound 4, half-maximal inhibitory concentration: 29900 nM
For compound 4 the middle estimate is 1.5-fold (0.18 log units) above the measured one; the range from low to high includes it.
By their numbers in this assay, from the lowest: compounds 1, 4, 3 and 2 (each within the scatter of the next).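

Within the data shown here, this is the first pair that differs in only one place, so it gives the first direct reading of a single swap in this assay. On the aromatic carbon next to the ring oxygen, 3-methoxyphenyl in place of 2-methylphenyl gives a 1.6-fold lower number from compound 3 to compound 4 (0.20 log units; within the scatter), so the two compounds cannot be told apart, even though the entering group adds an oxygen and a hydrogen-bond acceptor. Nothing measured here offers an explanation for this result.

The swap alters two things at once, the kind of small group on the aryl ring and where that group sits on it, and this single step cannot separate the two, nor can it show whether either alone would leave the read-out within the scatter. Going by these compounds, both groups are also six-membered aromatic rings of carbon only, so it remains open whether something quite different at this place, such as an amine, a carboxylic acid or a longer alkyl chain, would shift the number beyond the scatter.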